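The source may hold more compounds than are shown below. What is called first, only, known or untested is meant among the compounds shown, and "the series" means these compounds.

Compound 1 `O=C(CCN1CCC(c2nc(-c3ccccn3)no2)CC1)NC(c1ccc(Cl)cc1)c1ccc(Cl)cc1` was measured in an assay on isolated protein (plasma) for inhibition of lysosomal Pro-X carboxypeptidase (Mus musculus) (on this read-out lower numbers stand for stronger inhibition and higher numbers for weaker inhibition), and gives 305 nM. Compound 2 `C[C@H](NC(=O)CCN1CCC(c2nc(-c3ccccn3)no2)CC1)c1ccc(F)cc1` was measured in the same way and in this assay gives 348 nM. Among the two numbers known so far, compound 1 holds the lowest, but the gap to compound 2 lies within the scatter of repeated measurements, so the two cannot be told apart.

Compound 3 `O=C(CCN1CCC(c2ccccc2)CC1)NC(c1ccc(Cl)cc1)c1ccc(Cl)cc1` is the next compound in the series and has not yet been measured. It differs from compound 1 in one place: phenyl in place of 3-(pyridin-2-yl)-1,2,4-oxadiazol-5-yl on a saturated ring carbon. The phenyl that enters is smaller than the group that leaves and carries no hydrogen-bond acceptors. Going by the values given here, no pair of measured compounds shows what such a change does here, so any expectation rests on compound 1 alone.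

The step from compound 1 to compound 3 is expected to weaken inhibition well beyond the scatter, by about a 9.8-fold higher number from compound 1 to compound 3 (0.99 log units; beyond the scatter). On that basis compound 3 is estimated to give 3000 nM in this assay, with a plausible range from 600 nM to 15000 nM.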

Compound 3, half-maximal inhibitory concentration: 58 nM
Beside the measured number, compound 3's estimate is 52-fold (1.71 log units) above it; measured number outside the range, below it.
By their numbers in this assay, from the lowest: compound 3; then compounds 1 and 2 (each within the scatter of the next).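

At the saturated ring carbon three ring bonds from the ring nitrogen, the 3-(pyridin-2-yl)-1,2,4-oxadiazol-5-yl group of compound 1 proves not to be required for inhibition in this assay: exchanging it for phenyl gives a 5.3-fold lower number from compound 1 to compound 3 (0.72 log units; beyond the scatter). The entering group has fewer heavy atoms and carries no hydrogen-bond acceptors, so at this position, on the amide of compound 1, neither the larger group nor its acceptors are needed to reach the lower number of compound 3, which the two earlier compounds could not show. Nothing available accounts for this step, which therefore stands as an observation without an explanation.

Going by these compounds alone, the single step changes both aromatic rings and all of the hetero atoms at once, so it remains open whether a pyridin-2-yl group, a cyclohexyl ring or a 4-fluorophenyl group at the same ring carbon would follow compound 3 or compound 1. As far as these compounds go, it also remains open whether phenyl would bring a similar change on the amide of compound 2, where the shared core carries a different group.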